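The source may report more compounds than this note shows. Statements on the series, on what has been measured and on what is new or still open speak of the compounds shown alone.

Measured in a functional assay on HCT-116 cells (Homo sapiens) for antiproliferative activity, read by sulforhodamine B assay, with a stated time of 72 h; a lower number here means a stronger inhibitor, a higher number a weaker inhibitor:
- compound 1 `CNC(=O)C[C@@H]1C[C@@H](c2ccc(Cl)c(Cl)c2)[C@H](NC(=O)c2cc(-c3c(Cl)cnn3C)c(Cl)o2)CN1` gives 450 nM
- compound 2 `Cn1ncc(Cl)c1-c1cc(C(=O)N[C@@H]2CN[C@H](CC(O)CO)C[C@H]2c2ccc(F)c(F)c2)oc1Cl` gives 800 nM
- compound 3 `Cn1ncc(Cl)c1-c1cc(C(=O)N[C@@H]2CN[C@H](CC(O)CO)C[C@H]2c2ccc(Cl)c(Cl)c2)oc1Cl` gives 1110 nM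

Compound 3 lies close to compound 2 and further from compound 1. The change from 3,4-difluorophenyl to 3,4-dichlorophenyl stays within the scatter (a 1.4-fold higher number from compound 2 to compound 3 (0.14 log units; within the scatter)), while the side-chain change is modest (a 2.5-fold higher number from compound 1 to compound 3 (0.39 log units; beyond the scatter)).

Compound 4 `Cn1ncc(Cl)c1-c1cc(C(=O)N[C@@H]2CN[C@H](CCN3CCC(O)CC3)C[C@H]2c2ccc(Cl)c(Cl)c2)oc1Cl` differs from compound 3 at one place ((4-hydroxypiperidin-1-yl)methyl in place of 1,2-dihydroxyethyl on a saturated chain carbon bound to a saturated ring carbon), with (4-hydroxypiperidin-1-yl)methyl in place of 1,2-dihydroxyethyl on a saturated chain carbon bound to a saturated ring carbon. Only the modest side-chain step bears on this (a 2.5-fold higher number from compound 1 to compound 3 (0.39 log units; beyond the scatter)). For the measured compounds named here, no measured compound carries a ring there, so in this assay no step beyond the scatter is expected, and its direction is uncertain. The expected step is small (a 1.5-fold lower number from compound 3 to compound 4 (0.17 log units; within the scatter)). Compound 4 is estimated at 750 nM (expected range 280 nM to 2000 nM).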

Compound 4, half-maximal inhibitory concentration: 13700 nM
For compound 4 the middle estimate is 18-fold (1.26 log units) below the measured one; the whole stated range lies below it.
By their numbers in this assay, from the lowest: compounds 1, 2 and 3 (each within the scatter of the next, the first and the last beyond it); then compound 4.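

In this assay the saturated chain carbon bound to a saturated ring carbon proves sensitive to what it carries: (4-hydroxypiperidin-1-yl)methyl in place of 1,2-dihydroxyethyl gives a large loss (a 12-fold higher number from compound 3 to compound 4 (1.09 log units; beyond the scatter)), well past the modest earlier side-chain step (a 2.5-fold higher number from compound 1 to compound 3 (0.39 log units; beyond the scatter)). Against methylcarbamoyl the same group gives a still larger step (a 30-fold higher number from compound 1 to compound 4 (1.48 log units; beyond the scatter)). No evidence is available to explain this loss. As far as these compounds go, whether the ring, its hydroxyl or its nitrogen carries the loss stays open, as does how a morpholine or an open-chain tertiary amine would read here.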